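Isopropyl in Place of Methyl: Compound 2 to Compound 3

This account rests on a few compounds, and the source may have more. Where it says the series, first, only, none or still open, it means among the compounds named here.

Compound 1 `CC(=O)O[C@@H]1OC(=O)[C@](C)(C(C)=O)[C@@H]1C(C)C`: in a functional assay on B16 cells (Mus musculus) for cytotoxicity, read by MTT assay (a higher number here means a weaker inhibitor, a lower number a stronger inhibitor), compound 1 gives > 50000 nM, which is a limit of the assay, not a number.
Compound 2 `CC(=O)O[C@@H]1OC(=O)[C@@](C)(C(C)=O)[C@@H]1C`: in this assay compound 2 gives 14000 nM.

For the measured compounds named here, compound 2 thus holds the only measured number here; the other value reported is a limit (the limit of > 50000 nM in this assay, at which 1 of the 2 values shown sits). Compound 3 `CC(=O)O[C@@H]1OC(=O)[C@@](C)(C(C)=O)[C@@H]1C(C)C` differs from compound 2 by isopropyl in place of methyl on a saturated ring carbon. Going by the values given here, no comparable step between measured compounds is available to scale this change, so the expected step of a 1.8-fold higher number from compound 2 to compound 3 (0.25 log units; within the scatter) in this assay is uncertain and may not exceed the usual scatter. Compound 3 is estimated at 25000 nM, within 8000 nM to 80000 nM.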

Compound 3, half-maximal inhibitory concentration: > 50000 nM
Compound 3: no number, only a limit; the forecaster's own chance of this, stated with the estimate: 35%; middle value at least 2.0-fold (0.30 log units) away from the limit.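

Isopropyl in place of methyl on this saturated ring carbon gives, in this assay, an at least 3.5-fold higher number from compound 2 to compound 3 (0.55 log units; beyond the scatter), so this position does not tolerate the change without loss, which the earlier compounds could not show. The step between compound 1 and compound 3 cannot be read, as both values are limits of the assay: the limit of > 50000 nM in this assay, at which 2 of the 3 values shown sit. What separates the two is stereochemistry alone: the fact that compounds 1 and 3 differ only in the configuration as drawn

The compounds shown leave open whether an ethyl or a hydroxymethyl group on this ring carbon would stay closer to compound 2. They also leave open whether configuration at this carbon matters when methyl sits there.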